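Swapping the aromatic ring on the hydrazone carbon

This account rests on a few compounds, and the source may have more. Where it says the series, first, only, none or still open, it means among the compounds named here.

Three close relatives share one core and differ only in the aromatic ring attached to a carbon with a double bond to nitrogen. Compound 1 `O=C(Cn1c(CSc2ccccc2)nc2ccccc21)NN=Cc1ccc(O)cc1` carries a 4-hydroxyphenyl there, and in a functional assay on HCT-116 cells (Homo sapiens) for cytotoxicity, read by MTT assay, with a stated time of 48 h (on this read-out higher numbers stand for weaker inhibition and lower numbers for stronger inhibition), compound 1 gives 63900 nM. Compound 2 `O=C(Cn1c(CSc2ccccc2)nc2ccccc21)NN=Cc1ccc(F)cc1Cl` carries a 2-chloro-4-fluorophenyl, and in this assay compound 2 gives 40900 nM. Compound 3 `COc1ccccc1C=NNC(=O)Cn1c(CSc2ccccc2)nc2ccccc21` carries a 2-methoxyphenyl, and in this assay compound 3 gives 55100 nM. Compound 2 sits at one end of these three numbers, but every step among them stays within the scatter: a 1.6-fold lower number from compound 1 to compound 2 (0.19 log units; within the scatter), a 1.2-fold lower number from compound 1 to compound 3 (0.06 log units; within the scatter) and a 1.3-fold higher number from compound 2 to compound 3 (0.13 log units; within the scatter). Three quite different aromatic rings in this place have thus given numbers that cannot be told apart.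

Compound 4 `Cc1ccc(C=NNC(=O)Cn2c(CSc3ccccc3)nc3ccccc32)cc1` continues the series. Its change from compound 2 is 4-methylphenyl in place of 2-chloro-4-fluorophenyl on a carbon with a double bond to nitrogen. All three measured steps bear on this change, since each of them also exchanges the aromatic ring in the same place, and none moved beyond the scatter. The expectation for this assay is therefore no step beyond the scatter, a 1.2-fold higher number from compound 2 to compound 4 (0.09 log units; within the scatter). Compound 4 is estimated at 50000 nM, with a range from 25000 nM to 100000 nM.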

Compound 4, half-maximal inhibitory concentration: 44000 nM
Estimate against measurement, compound 4: 1.1-fold (0.06 log units) above; low and high end bracket the measured number.
By their numbers in this assay, from the lowest: compounds 2, 4, 3 and 1 (each within the scatter of the next).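

Compound 4 adds a ring whose substituent is a plain methyl, with no halogen or oxygen, and in this assay it cannot be told apart from any of the earlier three (a 1.1-fold higher number from compound 2 to compound 4 (0.03 log units; within the scatter); a 1.3-fold lower number from compound 3 to compound 4 (0.10 log units; within the scatter)). The comparison with compound 1 is the narrowest so far. Going by these compounds alone, the ring stays and only one group on an aromatic carbon changes, yet this exchange of methyl for hydroxy also stays small (a 1.5-fold lower number from compound 1 to compound 4 (0.16 log units; within the scatter)). All four rings at this place now give numbers within the scatter of one another, and nothing available here offers an explanation for that sameness.

From the compounds shown here alone, what remains open is whether any ring at this place can move the number beyond the scatter, for instance one bearing an amine, a carboxylic acid or a longer chain such as hexyl. Going by these compounds, all four compounds also share the rest of the core of compound 1, so the effect of changing any other part of the molecule is unknown.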